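This account rests on a few compounds, and the source may have more. Where it says the series, first, only, none or still open, it means among the compounds named here.

The measured compounds:
compound 1, `Cc1csc(N/C(S)=N/[C@@H](C)c2cccc3ccccc23)n1`, gives 83200 nM in a functional assay on RBL-2H3 cells (Rattus norvegicus) for inhibition; on this read-out lower numbers stand for stronger inhibition and higher numbers for weaker inhibition.
compound 2, `Cc1cc(C)nc(N/C(S)=N/[C@@H](C)c2cccc3ccccc23)c1`, gives > 100000 nM, which is a limit of this assay and not a number.
compound 3, `C[C@@H](/N=C(\S)Nc1nc2ccccc2s1)c1cccc2ccccc12`, gives 18900 nM.

Compound 3 holds the lowest of the two numbers in this assay; its nearest neighbour, compound 1, sits at a higher number, and that gap lies beyond the usual scatter. Compound 2 is known only as the limit of > 100000 nM in this assay, at which 1 of the 3 values shown sits.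

Compound 4, `Cc1cccc2sc(N/C(S)=N/[C@H](C)c3cccc4ccccc34)nc12`, is the compound not yet measured. It differs from compound 3 in one place: methyl in place of hydrogen on an aromatic carbon. Within the data shown here, the single measured step, an at least 1.2-fold higher number from compound 1 to compound 2 (0.07 log units; that floor lies within the scatter), exchanges the whole aromatic group on the amine nitrogen and so does not speak to a methyl entering a fused six-membered ring; no measured step bears on this change. With nothing to point either way, the expectation is a step of no more than the scatter, estimated as a 1.1-fold lower number from compound 3 to compound 4 (0.02 log units; within the scatter). Compound 4 is therefore expected to give about 18000 nM in this assay, within a range from 6000 nM to 55000 nM.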

Compound 4, half-maximal inhibitory concentration: > 100000 nM
Compound 4: a limit, no number (the forecaster's own chance of this, stated with the estimate: 5%); middle value at least 5.5-fold (0.74 log units) from the limit.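

In this assay, a methyl in place of hydrogen on an aromatic carbon, ortho to a fused ring and meta to a fused ring, brings an at least 5.2-fold higher number from compound 3 to compound 4 (0.72 log units; beyond the scatter). Among these compounds, the earlier compounds could not show this, as their only step exchanged the whole aromatic group on the amine nitrogen; here a single methyl on the fused system is enough for a change beyond the scatter. Compound 4 gives > 100000 nM, which is a limit of the assay and not a number, so the step has a floor and no measured size: the limit of > 100000 nM in this assay, at which 2 of the 4 values shown sit.

The compounds shown leave open how a chlorine, a methoxy group or an amine would read at this same aromatic carbon. They also leave open whether a methyl on the other aromatic carbons of that ring would read the same way.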